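Series notes: trifluoromethyl for isopropyl across two cores

A few compounds are considered here, and "the series" means these few. Any claim that something is new, unique, unknown or untested is made for them only; others in the source may bear on it.

Measured in a functional assay on mitochondria from heart for inhibition of peroxisomal acyl-coenzyme A oxidase 1 (Rattus norvegicus); on this read-out lower numbers stand for stronger inhibition and higher numbers for weaker inhibition:
compound 1 `Cc1nc2cc(OC[C@H](O)CN3CCN(Cc4noc(-c5ccc(C(C)C)cc5)n4)CC3)ccc2s1` gives 950 nM
compound 2 `Cc1nc2cc(OC[C@H](O)CN3CCN(Cc4noc(-c5ccc(C(F)(F)F)cc5)n4)CC3)ccc2s1` gives 380 nM
compound 3 `Cc1nc2cc(OC[C@H](O)CN3CCN(Cc4nc(-c5ccc(C(C)C)cc5)no4)CC3)ccc2s1` gives 1230 nM

Compound 1 and compound 3 are built from the same atoms joined differently; the difference between the two cores is not broken down here. Compound 3 shows the highest of the three numbers, with compound 1 within the scatter of it and compound 2 beyond it.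

Within the core of compound 1, the change trifluoromethyl in place of isopropyl on an aromatic carbon produced a 2.5-fold lower number from compound 1 to compound 2 (0.40 log units; beyond the scatter).

Compound 4 `Cc1nc2cc(OC[C@H](O)CN3CCN(Cc4nc(-c5ccc(C(F)(F)F)cc5)no4)CC3)ccc2s1` carries the same change on the core of compound 3: trifluoromethyl in place of isopropyl on an aromatic carbon. The two changes sit at places described in the same words, so this is taken as the same change rather than merely the same kind.

Going by the values given here, from compound 3 to compound 4 a step of a 2.5-fold lower number from compound 3 to compound 4 (0.40 log units; beyond the scatter) is expected in this assay, resting on the single earlier example a 2.5-fold lower number from compound 1 to compound 2 (0.40 log units; beyond the scatter); with one precedent only, the range is kept wide.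

Compound 4 is estimated at 490 nM, expected to fall between 250 nM and 1000 nM.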

Compound 4, half-maximal inhibitory concentration: 3630 nM
For compound 4 the middle estimate is 7.4-fold (0.87 log units) below the measured one; the measured number lies above the stated range.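

In this assay trifluoromethyl in place of isopropyl does not carry over between these two cores, as the new step, a 3.0-fold higher number from compound 3 to compound 4 (0.47 log units; beyond the scatter), runs opposite to the earlier one, and the gap between them is printed as real: the same change on two cores in this assay, a 2.5-fold lower number (0.40 log units; beyond the scatter) from compound 1 to compound 2 and a 3.0-fold higher number (0.47 log units; beyond the scatter) from compound 3 to compound 4, 7.4-fold (0.87 log units) apart, beyond the scatter of two such steps

For this pair of cores, the outcome of the change depends on the core that carries it, so a step read on one core gives no reliable estimate for the other. The series does not show why the cores part ways: two steps on a single read-out say nothing about the origin of the difference, and they set no rule for any further core.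

Open, on these data alone, is whether other groups on the same aromatic carbon, such as chlorine, a nitrile or a methoxy group, also move in opposite directions on the two cores. Equally open, as far as these compounds go, is whether an amine or a carboxylic acid at that place would give steps that agree between the core of compound 1 and the core of compound 3.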